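The compounds below may be only part of what the source reports. "The series", "measured", "known", "first", "only" and "open" are said of these compounds alone.

In a functional assay on SNU-638 cells (Homo sapiens) for cytotoxicity, read by sulforhodamine B assay, with a stated time of 72 h (on this read-out lower numbers stand for stronger inhibition and higher numbers for weaker inhibition), compound 1 `OCC1=C(F)[C@@H](n2cnc3c(NC4CC4)ncnc32)[C@H](O)[C@@H]1O` gives > 100000 nM, which is a limit and not a number. Compound 2 `Nc1nc(O)c2ncn([C@@H]3C(F)=C(CO)[C@@H](O)[C@H]3O)c2n1` gives > 100000 nM, also a limit. Going by the values given here, compound 3 `Nc1nc(N)c2ncn([C@@H]3C(F)=C(CO)[C@@H](O)[C@H]3O)c2n1` gives 32200 nM, the only true number so far. Compound 4 `Nc1nc(NC2CC2)c2ncn([C@@H]3C(F)=C(CO)[C@@H](O)[C@H]3O)c2n1` differs from compound 3 by cyclopropyl in place of hydrogen on a nitrogen on an aromatic ring, so amino becomes cyclopropylamino. Among the compounds with values here, the one measured step, an at least 3.1-fold lower number from compound 2 to compound 3 (0.49 log units; beyond the scatter), came with amino in place of hydroxy on an aromatic carbon. Compound 1 also carries cyclopropylamino and sits at the limit of > 100000 nM. A small move toward weaker inhibition is therefore expected. The expected change is a 2.2-fold higher number from compound 3 to compound 4 (0.34 log units; beyond the scatter). For compound 4, the estimated value is 70000 nM, within a range of 22000 nM to 100000 nM.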

Compound 4, half-maximal inhibitory concentration: > 100000 nM
Compound 4: a limit, no number; the forecaster's own chance of this, stated with the estimate: 50%; middle value at least 1.4-fold (0.15 log units) from the limit.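

Going by these compounds alone, until now the only readable step concerned hydroxy and amino on an aromatic carbon. Here, cyclopropyl in place of hydrogen on a nitrogen on an aromatic ring also moves the read-out, with an at least 3.1-fold higher number from compound 3 to compound 4 (0.49 log units; beyond the scatter) as the change, toward weaker inhibition. The steps to compound 4 from compound 1 and from compound 2 cannot be read because both members of each pair stand at a limit: the limit of > 100000 nM in this assay, at which 3 of the 4 values shown sit.

As far as these compounds go, whether methyl, or a longer chain such as n-butyl, on this nitrogen would give a true number stays open.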